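Stretching a Long Ester Chain on a Cytotoxicity Read-out

A few compounds are considered here, and "the series" means these few. Any claim that something is new, unique, unknown or untested is made for them only; others in the source may bear on it.

Compound 1 `CCCCCCCCCCOC(=O)CCC(=O)N1CCN(CCCOc2cc3c(Nc4ccc(F)c(Cl)c4)ncnc3cc2OC)CC1`: 95.7%
Compound 2 `CCCCCCCCCCCCOC(=O)CCC(=O)N1CCN(CCCOc2cc3c(Nc4ccc(F)c(Cl)c4)ncnc3cc2OC)CC1`: 95.5%

Both compounds were tested in a functional assay on A549 cells (Homo sapiens) for cytotoxicity, read by MTT assay, with a stated time of 24 h, tested at 10 uM; on this read-out lower numbers stand for a stronger effect and higher numbers for a weaker effect at the one concentration tested. Among the compounds with values here, compound 2 is one of only two measured numbers, and the step of a number 0.2 percentage points lower from compound 1 to compound 2 (within the scatter) lies within the scatter, so compound 1 and compound 2 stand level on this read-out: at the one concentration tested, neither shows a strong effect on the cells.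

Compound 3 `CCCCCCCCCCCCCCCCCCOC(=O)CCC(=O)N1CCN(CCCOc2cc3c(Nc4ccc(F)c(Cl)c4)ncnc3cc2OC)CC1` has not yet been measured. Its structure differs from compound 2 by hexyl in place of hydrogen on a saturated chain carbon, ten or more bonds along the chain from an oxygen next to a carbonyl group. Within the data shown here, the only measured step that bears on this change is a number 0.2 percentage points lower from compound 1 to compound 2 (within the scatter), a change of the same kind at the same place, and it was within the scatter. The step to compound 3 is a longer extension of the same chain, but nothing in the two numbers shown suggests that more chain alters the read-out.

Compound 3 is therefore expected to give 95% in this assay, with a range of 84% to 104%. The expected step is a number 0.5 percentage points lower from compound 2 to compound 3 (within the scatter), which stays within the scatter.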

Compound 3, a percentage reported as activity, at one concentration (the size of the read-out at that concentration, not a potency): 94.8%
Beside the measured number, compound 3's estimate is 0.2 percentage points above it; low and high end bracket the measured number.
By their numbers in this assay, from the lowest: compounds 3, 2 and 1 (each within the scatter of the next).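

With the hexyl on a saturated chain carbon, this assay gives a number 0.7 percentage points lower from compound 2 to compound 3 (within the scatter), which shows that a group of 6 carbon atoms at this place leaves the numbers level, where the earlier pair covered only an ethyl. The full span of the series, an octyl difference, gives a number 0.9 percentage points lower from compound 1 to compound 3 (within the scatter), so all three compounds stand level and these chains show no link between chain length and effect on the cells at the one concentration tested. No measurement shown here offers an explanation for this flat result.

The compounds shown leave open whether a much shorter chain, or a chain ending in an amine or a carboxylic acid, would give a different number at this place. They also leave open whether the three compounds would still stand level at another concentration or after a different exposure time.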